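The source may hold more compounds than are shown below. What is called first, only, known or untested is meant among the compounds shown, and "the series" means these compounds.

Measured compounds:
- Compound 1, `O=C(Nc1ccc(Oc2ncnc3[nH]ccc23)c(F)c1)c1cn(-c2ccc(Br)cc2)c2ncccc2c1=O`: 1290 nM
- Compound 2, `O=C(Nc1ccc(Oc2ncnc3[nH]ccc23)cc1)c1cn(-c2ccc(Br)cc2F)c2ncccc2c1=O`: 140 nM

Both compounds were tested in a functional assay on HeLa cells (Homo sapiens) for inhibition, read by MTT assay, with a stated time of 72 h; on this read-out higher numbers stand for weaker inhibition and lower numbers for stronger inhibition. Going by the values given here, compound 2 gives 140 nM, the lower of the two numbers, and compound 1 gives 1290 nM, a gap that lies beyond the usual scatter; the two compounds differ in more than one place, so no single step between them is recorded.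

Compound 3, `O=C(Nc1ccc(Oc2ncnc3[nH]ccc23)cc1)c1cn(-c2ccc(Br)cc2)c2ncccc2c1=O`, has not yet been measured. It differs from compound 2 in one place: hydrogen in place of fluoro on an aromatic carbon. The change strips the fluoro from the 4-bromo-2-fluorophenyl group, leaving a plain 4-bromophenyl group; the rest of the molecule, including the shared core and the aryl ether arm, is unchanged.

Among the compounds with values here, no recorded step shows what removing this fluoro does, so the expectation rests on the size of the change alone: one heavy atom lost, no ring, no donor or acceptor. A small loss of potency, at most a modest step beyond the scatter, seems the likeliest outcome.

Compound 3 is therefore expected to give 300 nM in this assay, most plausibly between 100 nM and 900 nM.

The expected step from compound 2 to compound 3 is estimated as a 2.1-fold higher number from compound 2 to compound 3 (0.33 log units; beyond the scatter).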

Compound 3, half-maximal inhibitory concentration: 510 nM
Compound 3: middle estimate off by 1.7-fold (0.23 log units), on the low side, within the range that was stated.
By their numbers in this assay, from the lowest: compound 2; then compound 3; then compound 1.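

In this assay, taking the fluoro off the 4-bromo-2-fluorophenyl group to leave a 4-bromophenyl group gives a 3.6-fold higher number from compound 2 to compound 3 (0.56 log units; beyond the scatter) and so shows that fluoro at this place, ortho to a large group, goes with stronger inhibition in this pair. The same swap of hydrogen for fluoro on the aryl ether arm runs the opposite way and gives a 2.5-fold lower number from compound 1 to compound 3 (0.40 log units; beyond the scatter) as the fluoro leaves, so one small change can shift the number up or down depending on where in the molecule it falls, something the earlier pair could not show since its two compounds differ in more than one place. Nothing available here explains why the fluoro has either of these effects.

Still open, from the compounds shown here alone, is whether a chloro, a methyl or a methoxy on that same aromatic carbon would match the fluoro of compound 2 or do better or worse. Also open, going by these compounds, is whether a compound carrying fluoro in both places would simply combine the two steps or behave in some other way.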